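Moving the methoxy group from compound 2 to compound 3

A few compounds are considered here, and "the series" means these few. Any claim that something is new, unique, unknown or untested is made for them only; others in the source may bear on it.

Measured so far in a functional assay on MCF7 cells (Homo sapiens) for inhibition, read by CCK-8 assay, with a stated time of 48 h; a lower number here means a stronger inhibitor of growth, a higher number a weaker inhibitor of growth:
- compound 1 `Cc1ccc(Nc2nc(Nc3ccc(N4CCN(C)CC4)cn3)ncc2Cl)cc1`: 11400 nM
- compound 2 `COc1ccc(Nc2nc(Nc3ccc(N4CCN(C)CC4)cn3)ncc2Cl)cc1`: 8450 nM

These two compounds share a core and differ only in one group on the aromatic ring. Within the data shown here, their numbers cannot be told apart: the only measured step is a 1.3-fold lower number from compound 1 to compound 2 (0.13 log units; within the scatter), with methoxy in place of methyl on an aromatic carbon. Compound 2 therefore stands level with compound 1, with no real separation in this assay.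

Compound 3 `COc1cccc(Nc2nc(Nc3ccc(N4CCN(C)CC4)cn3)ncc2Cl)c1` has the same atoms as compound 2, joined differently: 3-methoxyphenyl in place of 4-methoxyphenyl on a nitrogen on an aromatic ring. In words, this is 3-methoxyphenyl in place of 4-methoxyphenyl on a nitrogen on an aromatic ring.

Among the measured compounds shown here, no measured pair tests such a shift directly, so the evidence is thin. The nearest guide is the step that swapped the group itself, a 1.3-fold lower number from compound 1 to compound 2 (0.13 log units; within the scatter). On that basis, no change beyond the scatter is expected, in either direction.

The expected step is a 1.1-fold higher number from compound 2 to compound 3 (0.03 log units; within the scatter). For compound 3 the estimated value is 9000 nM, with an expected range from 4000 nM to 20000 nM.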

Compound 3, concentration for 50% growth inhibition: 7540 nM
Compound 3: middle estimate off by 1.2-fold (0.08 log units), on the high side, and the stated range covers the measured number.
By their numbers in this assay, from the lowest: compounds 3, 2 and 1 (each within the scatter of the next).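

In this assay, moving the methoxy group gives a 1.1-fold lower number from compound 2 to compound 3 (0.05 log units; within the scatter) with 3-methoxyphenyl in place of 4-methoxyphenyl on a nitrogen on an aromatic ring, so this assay cannot tell the two arrangements apart. The comparison that changes both the group and where it sits gives a 1.5-fold lower number from compound 1 to compound 3 (0.18 log units; within the scatter) with 3-methoxyphenyl in place of 4-methylphenyl, and this too stays within the usual scatter, so 4-methylphenyl, 4-methoxyphenyl and 3-methoxyphenyl all read alike at this place. No measurement is at hand that could explain this flat result.

The three compounds shown leave open whether a group of another kind on this ring, such as an amine, a carboxylic acid or a longer chain, would give a step beyond the scatter in this assay at all. The shared core is also the same in all three compounds, so they say nothing about how changes to the core itself would affect growth inhibition in these cells.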